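A 3-chlorophenyl group in place of pyridin-3-yl

This account rests on a few compounds, and the source may have more. Where it says the series, first, only, none or still open, it means among the compounds named here.

Compound 1 `Cc1cc(NC(=O)Nc2cccc([N+](=O)[O-])c2)c2ccccc2n1`: > 25000 nM (a limit)
Compound 2 `Cc1cc(NC(=O)Nc2cccnc2)c2ccccc2n1`: > 25000 nM (a limit)

Both compounds were tested in an ADME assay on HEK293 cells (Homo sapiens) for cytotoxicity, with a stated time of 72 h; a higher number here means that more compound is needed for the effect, a lower number that less compound is needed. Compound 2 gives > 25000 nM, which is a limit and not a number. Compound 1 gives > 25000 nM, which is also a limit. The two therefore share a single reading: the limit of > 25000 nM in this assay, at which 2 of the 2 values shown sit. Compound 2 has no numeric position of its own in this assay.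

Compound 3 `Cc1cc(NC(=O)Nc2cccc(Cl)c2)c2ccccc2n1` carries 3-chlorophenyl in place of pyridin-3-yl on an amide-type nitrogen. Among the measured compounds shown here, no step between measured compounds is available to size this change. The expectation rests on compound 1, which also lacks the pyridin-3-yl group and still gives > 25000 nM, a limit. No shift beyond the scatter is therefore expected in this assay, and the estimated change is an at least 1.1-fold lower number from compound 2 to compound 3 (0.05 log units; that floor lies within the scatter). For compound 3 the estimated value is 22000 nM, with an expected range of 9000 nM to 40000 nM.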

Compound 3, half-maximal effective concentration: 21000 nM
Compound 3: middle estimate off by 1.0-fold (0.02 log units), on the high side, and the stated range covers the measured number.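

Compound 3 gives a number rather than a limit in this assay, so this place on the amide-type nitrogen now has a numeric reading: compound 3 gives 21000 nM. From the compounds shown here alone, putting 3-chlorophenyl in place of pyridin-3-yl gives an at least 1.1-fold lower number from compound 2 to compound 3 (0.07 log units; that floor lies within the scatter), and chloro in place of nitro on an aromatic carbon gives an at least 1.1-fold lower number from compound 1 to compound 3 (0.07 log units; that floor lies within the scatter); each of these is only a floor, since its starting value is a limit, so the true size of either step remains unknown. Compound 1 and compound 2 still cannot be told apart from each other, and compound 3 does not change that, as their shared reading shows: the limit of > 25000 nM in this assay, at which 2 of the 3 values shown sit.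

The compounds shown leave open how far compound 1 and compound 2 really lie from compound 3 in this assay, and so whether either change has any effect beyond the usual scatter. Also open, going by these compounds, is how the reading would respond to an amine or a carboxylic acid in place of chloro on the aromatic carbon, since only chloro and nitro are compared there.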